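The compounds below may be only part of what the source reports. "The series", "measured", "known", "first", "only" and "open" are said of these compounds alone.

In a functional assay on Hep 3B2 cells (Homo sapiens) for inhibition, read by sulforhodamine B assay, with a stated time of 72 h (a higher number here means a weaker inhibitor, a lower number a stronger inhibitor), compound 1 `C[C@H](Nc1ncnc2[nH]cnc12)c1nn(-c2cccc(F)c2)c2cc(F)ccc12` gives > 40000 nM, which is a limit of the assay and not a number. This means compound 1 has no exact starting point from which to measure a change. Compound 2 `C[C@H](Nc1nc(N)nc(N)c1C#N)c1nn(-c2cccc(S(C)(=O)=O)c2)c2cc(Cl)ccc12` gives a true number of 5110 nM. It carries a 3-(methylsulfonyl)phenyl group but differs from compound 1 in other places too.

Compound 3 `C[C@H](Nc1ncnc2[nH]cnc12)c1nn(-c2cccc(S(C)(=O)=O)c2)c2cc(F)ccc12` keeps the rest of compound 1 and makes a single change, with methylsulfonyl in place of fluoro on an aromatic carbon. The 3-fluorophenyl group thus becomes 3-(methylsulfonyl)phenyl. Among the measured compounds shown here, no measured pair isolates this change, so its size remains uncertain. In this assay, a modest move towards stronger inhibition is expected because compound 2 reaches 5110 nM with the same group. Even so, compound 3 may well remain at the limit. The expected change is an at least 1.4-fold lower number from compound 1 to compound 3 (0.15 log units; that floor lies within the scatter). For compound 3, the estimated value is 28000 nM, with an expected range from 9000 nM to 60000 nM.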

Compound 3, half-maximal inhibitory concentration: 13000 nM
Beside the measured number, compound 3's estimate is 2.2-fold (0.33 log units) above it, and the stated range covers the measured number.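

In this assay, replacing fluoro with methylsulfonyl on this aromatic carbon, with the rest of compound 1 unchanged, gives an at least 3.0-fold lower number from compound 1 to compound 3 (0.48 log units; beyond the scatter) and so turns a result with no exact number into a measurable one. Among the compounds shown here, until now, the only sign that this group might help came from compound 2, which differs from compound 1 in other places too, whereas this pair isolates the change at this one position. As far as these compounds go, the true size of the step remains unknown, and the printed figure is only a floor, because compound 1 sits at a limit of the assay: the limit of > 40000 nM in this assay, at which 1 of the 3 values shown sits.

The compounds shown leave open whether the gain is particular to methylsulfonyl or whether another replacement for fluoro at the same place, such as a methoxy group, an amine or a carboxylic acid, would do as well or better. They also leave open whether the same swap would give a similar step on a different core, since compound 2 has no partner that differs from it only in this group.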